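From Amino to Methyl on an Aromatic Carbon

The source may report more compounds than this note shows. Statements on the series, on what has been measured and on what is new or still open speak of the compounds shown alone.

Measured compounds:
Compound 1, `CCOc1cc(C(Nc2ccc3c(N)nccc3c2)C(=O)NS(=O)(=O)c2ccc(O)cc2)ccc1OC(C)C`, in an assay on isolated protein for inhibition of Trypsin (Homo sapiens); a higher number here means a weaker inhibitor, a lower number a stronger inhibitor: > 5000 nM, a limit of the assay.
Compound 2, `CCOc1cc(C(Nc2ccc3c(N)nccc3c2)C(=O)NS(=O)(=O)c2ccc(N)cc2)ccc1OC(C)C`, in this assay: > 5000 nM, also a limit.

Compound 2 thus stands only at a limit in this assay, not at a number. The step that the two limits leave unreadable from compound 1 to compound 2 cannot be read because both ends sit at the limit of > 5000 nM in this assay, at which 2 of the 2 values shown sit.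

Compound 3, `CCOc1cc(C(Nc2ccc3c(N)nccc3c2)C(=O)NS(=O)(=O)c2ccc(C)cc2)ccc1OC(C)C`, differs from compound 2 by methyl in place of amino on an aromatic carbon. Going by the values given here, the only measured step that bears on this position of the shared core is a step that the two limits leave unreadable from compound 1 to compound 2, and it left no readable size. No step beyond the scatter is therefore expected in this assay, with an estimated step that the limit leaves unreadable from compound 2 to compound 3 from the limit. Compound 3 is expected at 10000 nM, in a range from 3000 nM to 40000 nM, most likely reported again only as a limit.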

Compound 3, inhibition constant: 3040 nM
Beside the measured number, compound 3's estimate is 3.3-fold (0.52 log units) above it; measured number inside the range.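

In this assay, going by these compounds alone, methyl on this aromatic carbon gives the only one of the three values that is a number and not a limit, so the 4-methylphenyl group gives this position its first readable point. Methyl in place of amino gives an at least 1.6-fold lower number from compound 2 to compound 3 (0.21 log units; that floor lies within the scatter), and methyl in place of hydroxy gives an at least 1.6-fold lower number from compound 1 to compound 3 (0.21 log units; that floor lies within the scatter); both are floors, so the true size of each step remains unknown and neither shows a difference beyond the scatter. Compound 1 and compound 2 remain at limits of the assay, and the step between them cannot be read: the limit of > 5000 nM in this assay, at which 2 of the 3 values shown sit.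

The compounds shown leave open whether a longer chain such as ethyl on this carbon would also give a number, and how its value would compare with that of compound 3. They also leave open how chlorine or a carboxylic acid would read at this position.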